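A Branched Chain Straightened on the Core of Compound 3

A few compounds are considered here, and "the series" means these few. Any claim that something is new, unique, unknown or untested is made for them only; others in the source may bear on it.

Three ureas that share one core have been run in an ADME assay on the whole organism with Oryza sativa as the target, tested at 1 uM; on this read-out higher numbers stand for a weaker effect at the one concentration tested and lower numbers for a stronger effect. Compound 1 `Cc1ccc(NC(=O)N[C@H](C)c2ccccc2)cc1` gives 98%. Compound 2 `CC(C)c1ccc(NC(=O)N[C@H](C)c2ccccc2)cc1` gives 79%, and compound 3 `C[C@@H](NC(=O)Nc1ccc(C(C)(C)C)cc1)c1ccccc1` gives 88%. Among these three numbers compound 3 stands second highest; its nearest neighbour is compound 2 and its furthest is compound 1, and both gaps lie within the usual scatter, so no order can be read between compound 3 and either of them.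

Compound 4 `CCCCc1ccc(NC(=O)N[C@H](C)c2ccccc2)cc1` has not yet been tested. It differs from compound 3 in one place: butyl in place of tert-butyl on an aromatic carbon; the two have the same atoms, joined differently.

For the measured compounds named here, none of the measured steps swaps one way of joining the same atoms for another, so no step bears directly on this change. The steps that come closest exchange the group on the same aromatic carbon: a number 19 percentage points lower from compound 1 to compound 2 (beyond the scatter), a number 10 percentage points lower from compound 1 to compound 3 (within the scatter) and a number 9 percentage points higher from compound 2 to compound 3 (within the scatter). Only the first of these falls beyond the scatter, and the three together show no consistent direction. A change that keeps the same atoms and only rearranges the chain is therefore expected to give a step of a number 3 percentage points lower from compound 3 to compound 4 (within the scatter), that is, none beyond the scatter. Compound 4 is thus estimated at 85%, with a range from 70% to 98%.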

Compound 4, a percentage reported as activity, at one concentration (the size of the read-out at that concentration, not a potency): 32%
The estimate for compound 4 lay 53 percentage points above the measured number; the whole stated range lies above it.
By their numbers in this assay, from the lowest: compound 4; then compounds 2, 3 and 1 (each within the scatter of the next, the first and the last beyond it).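

In this assay the same atoms joined differently are far from an even swap on this aromatic carbon: butyl in place of tert-butyl gives a number 56 percentage points lower from compound 3 to compound 4 (beyond the scatter) and so the way the chain is joined counts here, not only the atoms it holds. The straight chain also stands apart from the smaller groups on the same carbon, with a number 47 percentage points lower from compound 2 to compound 4 (beyond the scatter) and with a number 66 percentage points lower from compound 1 to compound 4 (beyond the scatter) as well, and both of these steps are much larger than any step among compound 1, compound 2 and compound 3. Nothing available explains why butyl behaves so differently from tert-butyl at this position.

With butyl as the only straight chain of more than one carbon, the compounds shown cannot tell whether the stronger effect depends on chain length, on the absence of branching, or on both. A propyl or pentyl chain would test the length, and an isobutyl group, with its branch further out along the chain, would show how much branching matters and where along the chain it counts.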